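Aryl substituent change in a quinoline amide series

The source may report more compounds than this note shows. Statements on the series, on what has been measured and on what is new or still open speak of the compounds shown alone.

Measured compounds:
compound 1 `COc1cc2c(Oc3ccc(NC(=O)c4nn(-c5ccccc5C)c(=O)cc4C)cc3F)ccnc2cc1OCCCN1CCCCC1` — 1310 nM
compound 2 `COc1cc2c(Oc3ccc(NC(=O)c4nn(-c5ccccc5C)c(=O)cc4C)cc3F)ccnc2cc1OCCCN1CCN(C)CC1` — 1630 nM

In a functional assay on MKN-45 cells (Homo sapiens) for inhibition, read by MTT assay, with a stated time of 72 h (a lower number here means a stronger inhibitor, a higher number a weaker inhibitor), compound 1 gives 1310 nM and compound 2 gives 1630 nM. Within the data shown here, compound 2 holds the higher of the two numbers, with compound 1 its only neighbour; the step is a 1.2-fold higher number from compound 1 to compound 2 (0.09 log units; within the scatter), so the two compounds are not separated on this read-out. That step concerns the amine at the end of the chain and nothing else.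

Compound 3 `COc1cc2c(Oc3ccc(NC(=O)c4nn(-c5ccccc5OC(F)(F)F)c(=O)cc4C)cc3F)ccnc2cc1OCCCN1CCN(C)CC1` differs from compound 2 in one place: trifluoromethoxy in place of methyl on an aromatic carbon. Among the measured compounds shown here, no measured step touches this part of the molecule, so the only measured step, a 1.2-fold higher number from compound 1 to compound 2 (0.09 log units; within the scatter), gives no guidance on it. The expectation for compound 3 therefore rests on compound 2 alone, with wide uncertainty in both directions.

For compound 3 the estimate is 1600 nM, range 500 nM to 5000 nM, which corresponds to an expected step of a 1.0-fold lower number from compound 2 to compound 3 (0.01 log units; within the scatter) and thus to no change beyond the scatter.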

Compound 3, half-maximal inhibitory concentration: 100 nM
Compound 3: the middle estimate sits 16-fold (1.20 log units) above what was measured; the whole stated range lies above it.
By their numbers in this assay, from the lowest: compound 3; then compounds 1 and 2 (each within the scatter of the next).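

The 2-methylphenyl to 2-(trifluoromethoxy)phenyl change gives a 16-fold lower number from compound 2 to compound 3 (1.21 log units; beyond the scatter) in this assay, which shows that this aromatic carbon, ortho to a large group, is a position where the read-out responds strongly to the substituent. Among these compounds, the earlier pair showed only that the amine at the end of the chain, a 1.2-fold higher number from compound 1 to compound 2 (0.09 log units; within the scatter), did not separate its two compounds, so among the pairs at hand the aryl substituent is the only single change with a step beyond the scatter. Nothing available explains the size of this step or connects it to any measured property of the trifluoromethoxy group.

Still open, as far as these compounds go, is which part of the trifluoromethoxy group matters, since methoxy or trifluoromethyl on the same aromatic carbon would separate the contribution of the oxygen from that of the fluorines. Also open, from the compounds shown here alone, is whether the step carries over to the piperidin-1-yl chain end of compound 1, which would show whether the aryl change acts independently of the amine.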